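The source may report more compounds than this note shows. Statements on the series, on what has been measured and on what is new or still open speak of the compounds shown alone.

Measured compounds:
compound 1 `Cc1nn(-c2ccccc2)c2nc(-c3ccccc3)c(C#N)c(-c3ccccc3O)c12` — > 23000 nM
compound 2 `CCc1ccc(-c2nc3c(c(C)nn3-c3ccccc3)c(-c3ccccc3OC)c2C#N)cc1` — > 20000 nM

In an ADME assay on BJ cells (Homo sapiens) for cytotoxicity, with a stated time of 72 h (a lower number here means that less compound is needed, a higher number that more compound is needed for the effect), compound 1 gives > 23000 nM, which is a limit of the assay and not a number. Compound 2 likewise gives only a limit there, > 20000 nM. Compound 1 thus sits at the limit of > 23000 nM in this assay, at which 1 of the 2 values shown sits. Compound 3 `Cc1nn(-c2ccccc2)c2nc(-c3ccc(I)cc3)c(C#N)c(-c3ccccc3O)c12` differs from compound 1 by iodo in place of hydrogen on an aromatic carbon. Among the compounds with values here, no measured pair isolates this change, so the step that the limit leaves unreadable from compound 1 to compound 3 is expected to stay within the scatter, with no clear direction. Compound 3 is therefore expected to give about 30000 nM in this assay, between 10000 nM and 100000 nM, most likely reported again only as a limit.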

Compound 3, half-maximal effective concentration: 19000 nM
Compound 3: the middle estimate sits 1.6-fold (0.20 log units) above what was measured; low and high end bracket the measured number.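

In this assay compound 3 gives 19000 nM as an actual number, the only one among the compounds shown, so iodo at this place on the six-membered aromatic ring gives a readable value. The change amounts to an at least 1.2-fold lower number from compound 1 to compound 3 (0.08 log units; that floor lies within the scatter) and shows no step beyond the scatter. Compound 1 has only a limit of the assay, so the true size of the step cannot be read: the limit of > 23000 nM in this assay, at which 1 of the 3 values shown sits.

The compounds shown leave open whether chloro, bromo or an amine at this place would give a number as well. They also leave open how iodo would read on compound 2.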